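The source may hold more compounds than are shown below. What is called first, only, known or untested is meant among the compounds shown, and "the series" means these compounds.

Measured so far:
compound 1, `COc1cccc(-c2nc3cccc(-c4cc(OC)c(OC)c(OC)c4)c3o2)c1`, > 25000 nM
compound 2, `COc1ccc(-c2nc3cccc(-c4cc(OC)c(OC)c(OC)c4)c3o2)cc1F`, 2800 nM

Compound 1 reaches only a limit of the assay in a functional assay on NCI-H460 cells (Homo sapiens) for antiproliferative activity, read by MTT assay, with a stated time of 48 h; on this read-out lower numbers stand for stronger inhibition and higher numbers for weaker inhibition: its value of > 25000 nM is a limit, not a number. Compound 2 gives 2800 nM in this assay. Going by the values given here, the single measured step, an at least 8.9-fold lower number from compound 1 to compound 2 (0.95 log units; beyond the scatter), is the only comparison available, and it rests on (the limit of > 25000 nM in this assay, at which 1 of the 2 values shown sits). Compound 3, `COc1cc(-c2cccc3nc(-c4cccc(F)c4)oc23)cc(OC)c1OC`, differs from compound 1 by fluoro in place of methoxy on an aromatic carbon; cut one bond further out, the change reads 3-methoxyphenyl to 3-fluorophenyl, meta to a large group. Among the compounds with values here, no measured step shows a fluoro replacing a methoxy at this place; the step from compound 1 to compound 2 moved the methoxy and added a fluoro at once, so it bears only loosely here. For compound 3 the expected step is therefore modest and uncertain, an at least 1.6-fold lower number from compound 1 to compound 3 (0.22 log units; that floor lies within the scatter). Compound 3 is estimated at 15000 nM, between 4000 nM and 50000 nM.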

Compound 3, half-maximal inhibitory concentration: 3300 nM
Beside the measured number, compound 3's estimate is 4.5-fold (0.66 log units) above it; measured number below the stated range.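

In this assay, replacing the methoxy of the 3-methoxyphenyl with fluoro, with nothing else changed, gives an at least 7.5-fold lower number from compound 1 to compound 3 (0.87 log units; beyond the scatter), so this one exchange alone is enough to turn a compound without a measurable number into one with a measured value. Taking the methoxy off the fluorinated ring of compound 2 and leaving hydrogen gives a 1.2-fold higher number from compound 2 to compound 3 (0.07 log units; within the scatter), so that extra methoxy makes no readable difference on a ring that already carries fluoro. The first step gives only a minimum size, since the value for compound 1 is a limit: the limit of > 25000 nM in this assay, at which 1 of the 3 values shown sits.

Going by these compounds, whether the gain comes from the fluoro itself or simply from losing the methoxy stays open, and a plain phenyl would separate the two. How a chloro, a nitrile or an amine would behave on this ring is also unknown.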